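The source may report more compounds than this note shows. Statements on the series, on what has been measured and on what is new or still open speak of the compounds shown alone.

Compound 2 `Oc1ccc(O)c(-c2cc(-c3ccccc3)nn2-c2ccccc2)c1` is the starting point of this account. In a functional assay on cells (Cancer cell lines, Homo sapiens) for cytotoxicity, read by sulforhodamine B assay, with a stated time of 48 h (a higher number here means a weaker inhibitor of growth, a lower number a stronger inhibitor of growth), compound 2 gives 67300 nM, the highest of the three numbers recorded, and its nearest neighbour is compound 1 `COc1ccc(OC)c(-c2cc(-c3ccccc3)nn2-c2ccc(S(=O)(=O)NC(C)=O)cc2)c1`, which in this assay gives 37700 nM, within the scatter of compound 2. Within the data shown here, compound 3 `Oc1ccc(O)c(-c2cc(-c3ccc(Cl)cc3)nn2-c2ccccc2)c1` gives 32000 nM in this assay, and the single-point step a 2.1-fold lower number from compound 2 to compound 3 (0.32 log units; beyond the scatter) is the only measured step among the three.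

Compound 4 `CC(=O)NS(=O)(=O)c1ccc(-n2nc(-c3ccccc3)cc2-c2cc(O)ccc2O)cc1` differs from compound 2 in one place: acetylsulfamoyl in place of hydrogen on an aromatic carbon. Among the measured compounds shown here, no measured step describes this change on its own. Compound 1 carries the same acetylsulfamoyl group, but it also differs from compound 2 in two other places, and its number and that of compound 2 are within the scatter of each other. The measured step from compound 2 to compound 3 concerns a different change and gives no direct guidance. The account therefore expects a step of a 1.3-fold lower number from compound 2 to compound 4 (0.13 log units; within the scatter) that stays within or near the scatter. For compound 4 the estimated value in this assay is 50000 nM, with an expected range from 20000 nM to 120000 nM.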

Compound 4, concentration for total growth inhibition: 100000 nM
Compound 4: middle estimate off by 2.0-fold (0.30 log units), on the low side; low and high end bracket the measured number.
By their numbers in this assay, from the lowest: compounds 3, 1, 2 and 4 (each within the scatter of the next, the first and the last beyond it).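

In this assay, placing acetylsulfamoyl on an aromatic carbon, para to a large group, gives a 1.5-fold higher number from compound 2 to compound 4 (0.17 log units; within the scatter) and so moves the number no further than the scatter. Among these compounds, with acetylsulfamoyl held in place, the change to 2,5-dihydroxyphenyl in place of 2,5-dimethoxyphenyl gives a 2.7-fold higher number from compound 1 to compound 4 (0.42 log units; beyond the scatter) and is the first measured step at that site, a modest one that shows the site can shift the number even where acetylsulfamoyl could not. Nothing available explains either step.

On these data alone, whether the step at that site would recur without acetylsulfamoyl remains open, as compound 1 and compound 4 show it only with that group present. The compounds shown also leave open how an amine or a carboxylic acid would behave on the same aromatic carbon.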